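The compounds below may be only part of what the source reports. "The series", "measured", "known", "first", "only" and "open" are said of these compounds alone.

In a functional assay on HepG2 cells (Homo sapiens) for antiproliferative activity, read by CCK-8 assay, with a stated time of 72 h, tested at 8 uM (a higher number here means a stronger effect of the compound at the concentration tested, a lower number a weaker effect), three compounds have been measured. Compound 1 `Nc1ccccc1NC(=O)/C=C/c1ccc(COCNc2nc(Nc3cccc(Cl)c3)c3ncn(C4CCCC4)c3n2)cc1` gives 14.8%. Compound 2 `CC(C)n1cnc2c(Nc3cccc(Cl)c3)nc(NCOCc3ccc(C(=O)Nc4ccccc4N)cc3)nc21` gives 60.5%, and compound 3 `CCCCn1cnc2c(Nc3cccc(Cl)c3)nc(NCOCc3ccc(C(=O)Nc4ccccc4N)cc3)nc21` gives 63.1%, the highest of the three numbers, although the gap to compound 2 lies within the scatter; only the gap to compound 1 lies beyond it.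

Compound 4 `Nc1ccccc1NC(=O)c1ccc(COCNc2nc(Nc3cccc(Cl)c3)c3ncn(C4CCCC4)c3n2)cc1` has not yet been measured. It differs from compound 3 in one place: cyclopentyl in place of butyl on an aromatic nitrogen.

Within the data shown here, the one measured step that bears on this change is the exchange of one alkyl group for another on the same aromatic nitrogen, a number 2.6 percentage points higher from compound 2 to compound 3 (within the scatter), which did not move the number beyond the scatter. Compound 1 also carries the cyclopentyl group, but it differs from the other compounds in a second place as well, so its low number cannot be tied to the cyclopentyl group alone.

From this single small step, compound 4 is expected to stay close to compound 3, with a step of about a number 5.1 percentage points lower from compound 3 to compound 4 (within the scatter) and no change beyond the scatter. The estimate for compound 4 in this assay is 58%, with a range from 35% to 75%.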

Compound 4, a percentage reported as inhibition, at one concentration (the size of the read-out at that concentration, not a potency): 63.2%
The estimate for compound 4 lay 5.2 percentage points below the measured number; the range from low to high includes it.
By their numbers in this assay, from the lowest: compound 1; then compounds 2, 3 and 4 (each within the scatter of the next).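

In this assay, cyclopentyl in place of butyl on the aromatic nitrogen gives a number 0.1 percentage points higher from compound 3 to compound 4 (within the scatter), and cyclopentyl in place of isopropyl gives a number 2.7 percentage points higher from compound 2 to compound 4 (within the scatter), so a ring of carbon at this position reads the same as the two open alkyl groups. With cyclopentyl kept, (2-aminophenyl)carbamoyl in place of 2-((2-aminophenyl)carbamoyl)ethenyl on an aromatic carbon gives a number 48.4 percentage points higher from compound 1 to compound 4 (beyond the scatter), which ties the low number of compound 1 to that other place and not to cyclopentyl. Nothing available explains either result.

Going by these compounds, whether this position accepts groups other than plain alkyl stays open, for example a benzyl group or a hydroxyethyl chain. A reading at one concentration also leaves open whether compound 2, compound 3 and compound 4 would show a stronger or weaker effect than one another at other concentrations.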